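Direct aryl in place of benzyl on the fused core

This account rests on a few compounds, and the source may have more. Where it says the series, first, only, none or still open, it means among the compounds named here.

Within the data shown here, compound 2 `C=C(Br)C(=O)Nc1cccc(-c2cn3nc(Cc4ccccc4)sc3n2)c1` gives 4200 nM in a functional assay on CCRF-CEM cells (Homo sapiens) for inhibition, read by cell counting, with a stated time of 3 days (a lower number here means a stronger inhibitor, a higher number a weaker inhibitor), and the sole neighbour, compound 1 `C=C(Br)C(=O)Nc1cccc(-c2cn3nc(Cc4cccc(OC)c4)sc3n2)c1` with 3100 nM, sits within the scatter, as a 1.4-fold higher number from compound 1 to compound 2 (0.13 log units; within the scatter) shows. Compound 3 `C=C(Br)C(=O)Nc1cccc(-c2cn3nc(-c4ccc(OCC)cc4)sc3n2)c1` carries 4-ethoxyphenyl in place of benzyl on an aromatic carbon. Among the measured compounds shown here, no measured step exchanges a benzyl for a 4-ethoxyphenyl group, so the one step in hand, which concerns only a methoxy, offers no direction, and the expected change is one within the scatter, a 1.2-fold lower number from compound 2 to compound 3 (0.08 log units; within the scatter). For compound 3 the estimate in this assay is 3500 nM, with a range from 900 nM to 14000 nM.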

Compound 3, half-maximal inhibitory concentration: 1400 nM
Estimate against measurement, compound 3: 2.5-fold (0.40 log units) above; the range from low to high includes it.
By their numbers in this assay, from the lowest: compound 3; then compounds 1 and 2 (each within the scatter of the next).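

Among these compounds, at this aromatic carbon, the earlier compounds offered only a methoxy change within the scatter, whereas 4-ethoxyphenyl in place of benzyl moves the number beyond the scatter in this assay (a 3.0-fold lower number from compound 2 to compound 3 (0.48 log units; beyond the scatter)). The exchange for 3-methoxybenzyl also lies beyond the scatter (a 2.2-fold lower number from compound 1 to compound 3 (0.35 log units; beyond the scatter)), so compound 3 is the strongest inhibitor of the three, though only modestly. Nothing available accounts for this gain. Whether it follows from the directly attached ring or from the ethoxy group remains unseparated, as both differ at once. As far as these compounds go, how an amine, a carboxylic acid or a longer chain in place of the ethoxy group would fare also remains open.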